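Methoxy in place of methyl: cytotoxicity still at the limit

A few compounds are considered here, and "the series" means these few. Any claim that something is new, unique, unknown or untested is made for them only; others in the source may bear on it.

Compound 1 `O=c1nc(-c2ccccc2)c2cc(-c3ccccc3)ccc2[nH]1` gives > 50000 nM in an ADME assay on L6 cells (Rattus norvegicus) for cytotoxicity, read by fluorescence and resazurin assay, with a stated time of 72 h (a lower number here means that less compound is needed, a higher number that more compound is needed for the effect), a limit of the assay.
Compound 2 `O=c1nc(-c2ccccc2)c2cc(-c3cc[nH]n3)ccc2[nH]1` gives > 50000 nM in this assay, again a limit.
Compound 3 `Cc1ccccc1-c1nc(=O)[nH]c2ccc(-c3cc[nH]n3)cc12` gives > 50000 nM in this assay, also a limit.

Among the compounds with values here, compound 3 therefore stands where every value so far stands: at the limit of > 50000 nM in this assay, at which 3 of the 3 values shown sit. The next compound, compound 4 `COc1ccccc1-c1nc(=O)[nH]c2ccc(-c3cc[nH]n3)cc12`, differs from it by methoxy in place of methyl on an aromatic carbon. Within the data shown here, two steps bear on this change: a step that the two limits leave unreadable from compound 1 to compound 2 and a step that the two limits leave unreadable from compound 2 to compound 3. Among the measured compounds shown here, neither can be read, so no step in this assay can be expected in either direction beyond the scatter. Compound 4 is thus estimated to sit at 80000 nM, within 40000 nM to 200000 nM, and the expected step from compound 3 is a step that the limit leaves unreadable from compound 3 to compound 4, most likely reported again only as a limit.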

Compound 4, half-maximal effective concentration: > 50000 nM
Compound 4: only a limit was reported; the forecaster's own chance of this, stated with the estimate: 85%; the middle value lies beyond the limit too.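

Neither step to compound 4, from compound 2 or from compound 3, can be read, as compound 4 again gives only a limit in this assay: the limit of > 50000 nM in this assay, at which 4 of the 4 values shown sit. The compounds shown leave open how far any of the four lies beyond that limit, and whether methoxy in place of methyl changes the concentration needed at all.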